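The source may hold more compounds than are shown below. What is called first, only, known or untested is meant among the compounds shown, and "the series" means these compounds.

Among the measured compounds shown here, compound 3, `O=C(CCCCCCc1ccccc1)c1ncc(-c2ncccn2)o1`, gives 5.3 nM in an assay (Rattus norvegicus) for inhibition of Fatty-acid amide hydrolase 1 (Homo sapiens) (a higher number here means a weaker inhibitor, a lower number a stronger inhibitor), the lowest of the three numbers known. Compound 1, `O=C(CCCCCCc1ccccc1)c1ncc(-c2ccc([N+](=O)[O-])cc2)o1`, gives 50 nM in this assay, and compound 2, `O=C(CCCCCCc1ccccc1)c1ncc(-c2ccc(F)cc2)o1`, gives 62 nM. The steps run a 9.4-fold lower number from compound 1 to compound 3 (0.97 log units; beyond the scatter) and a 12-fold lower number from compound 2 to compound 3 (1.07 log units; beyond the scatter), while a 1.2-fold higher number from compound 1 to compound 2 (0.09 log units; within the scatter). Compound 4, `CN1CCN(C(=O)c2cnc(C(=O)CCCCCCc3ccccc3)o2)CC1`, carries (4-methylpiperazin-1-yl)carbonyl in place of pyrimidin-2-yl on an aromatic carbon. For the measured compounds named here, no measured step swaps an aromatic ring for a carbonyl-linked non-aromatic ring at this position, so the only guide is that changing this group moved the numbers in both known steps. For compound 4 a modest rise in number is expected, a 5.7-fold higher number from compound 3 to compound 4 (0.75 log units; beyond the scatter), with an estimate of 30 nM in this assay, plausibly between 5 nM and 200 nM.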

Compound 4, inhibition constant: 80 nM
Compound 4: the middle estimate sits 2.7-fold (0.43 log units) below what was measured, and the stated range covers the measured number.
By their numbers in this assay, from the lowest: compound 3; then compounds 1, 2 and 4 (each within the scatter of the next).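

In this assay, replacing pyrimidin-2-yl with (4-methylpiperazin-1-yl)carbonyl gives a 15-fold higher number from compound 3 to compound 4 (1.18 log units; beyond the scatter), so the low number does not carry over to every group at this position. The non-aromatic ring joined through a carbonyl instead sits level with the 4-fluorophenyl and 4-nitrophenyl groups, at a 1.3-fold higher number from compound 2 to compound 4 (0.11 log units; within the scatter) and a 1.6-fold higher number from compound 1 to compound 4 (0.20 log units; within the scatter), leaving pyrimidin-2-yl alone in standing apart. Nothing available explains this difference. Still open, as far as these compounds go, is whether a pyridin-2-yl or unsubstituted phenyl group would match pyrimidin-2-yl, and whether a morpholine amide would match the methylpiperazine amide.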